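The compounds below may be only part of what the source reports. "The series", "measured", "known", "first", "only" and "open" are said of these compounds alone.

Of the compounds shown here, three built on one shared core have been measured in a functional assay, with a stated time of 150 min, tested at 20 ug/mL; on this read-out higher numbers stand for a stronger effect at the one concentration tested and lower numbers for a weaker effect. Compound 1 `COC(=O)c1c(Nc2ccccc2)sc(C(=O)c2ccc(OC)cc2)c1C` gives 32.4% in this assay. Compound 2 `COC(=O)c1c(Nc2ccc(Cl)cc2)sc(C(=O)c2ccc(C)cc2)c1C` is reported in this assay as "not active" (no number reported), with no number attached. Compound 3 `COc1ccc(C(=O)c2sc(Nc3ccccc3)c(C(=O)O)c2C)cc1` gives 41.2% in this assay. The one measured step between compounds differing in a single place is a number 8.8 percentage points higher from compound 1 to compound 3 (within the scatter), so on the numbers shown compound 3 and compound 1 lie within the scatter of each other, while compound 2 contributes no number at all.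

Compound 4 `COc1ccc(C(=O)c2sc(Nc3ccc(Cl)cc3)c(C(=O)O)c2C)cc1` differs from compound 3 in one place: chloro in place of hydrogen on an aromatic carbon. Among the compounds with values here, no measured step alters this one place on its own, so the data give no direct size for it. Within the data shown here, the only measured compound carrying a chloro group is compound 2, which this assay reports as "not active" (no number reported), though compound 2 also differs from compound 4 elsewhere, so its result only hints at a weaker outcome. Compound 4 is therefore estimated to give 25%, with a range from 5% to 45%. The expected step is a number 16.2 percentage points lower from compound 3 to compound 4 (beyond the scatter), downward but uncertain, with a real chance that only "not active" is reported.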

Compound 4, a percentage reported as activity, at one concentration (the size of the read-out at that concentration, not a potency): "not active" (no number reported)
For compound 4 the study gives words and no number; the estimate stays without a comparison.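

Compound 4 is reported in words rather than as a number, so no new step can be read between compound 3 and compound 4. The compounds shown leave open how large the effect of the chloro group is, and no measurement here explains the result.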